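A few compounds are considered here, and "the series" means these few. Any claim that something is new, unique, unknown or untested is made for them only; others in the source may bear on it.

- compound 1 `O=C(NCCCNc1cc(-c2cn(-c3ccccc3)nc2-c2cccc(O)c2)ccn1)Nc1ccc(F)cc1` gives 980 nM here
- compound 2 `O=C(NCCCNc1cc(-c2cn(-c3ccccc3)nc2-c2cccc(O)c2)ccn1)Nc1cccc(C(F)(F)F)c1` gives 1340 nM here

In a functional assay on Hs-578T cells (Homo sapiens) for antiproliferative activity, read by sulforhodamine B assay, with a stated time of 48 h (on this read-out lower numbers stand for stronger inhibition and higher numbers for weaker inhibition), compound 1 cannot be told apart from compound 2 and a 1.4-fold higher number from compound 1 to compound 2 (0.14 log units; within the scatter) is the whole gap between them. That step swaps 4-fluorophenyl for 3-(trifluoromethyl)phenyl and leaves the oxygen untouched. Compound 3 `COc1cccc(-c2nn(-c3ccccc3)cc2-c2ccnc(NCCCNC(=O)Nc3ccc(F)cc3)c2)c1` differs from compound 1 by methyl in place of hydrogen on an oxygen on an aromatic ring and so has methyl in place of hydrogen on an oxygen on an aromatic ring, turning 3-hydroxyphenyl into 3-methoxyphenyl. Among the measured compounds shown here, no measured step covers this change, so its direction is unknown and no step beyond the scatter is expected. The estimated step is a 1.5-fold higher number from compound 1 to compound 3 (0.18 log units; within the scatter) and remains uncertain. For compound 3 the estimate is 1500 nM with an expected range from 500 nM to 5000 nM in this measurement.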

Compound 3, half-maximal inhibitory concentration: 6240 nM
Compound 3: middle estimate off by 4.2-fold (0.62 log units), on the low side; measured number above the stated range.
By their numbers in this assay, from the lowest: compounds 1 and 2 (each within the scatter of the next); then compound 3.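

Among the compounds shown here, putting methyl on the oxygen of the 3-hydroxyphenyl group gives the first step in this assay that lies beyond the scatter, with a 6.4-fold higher number from compound 1 to compound 3 (0.80 log units; beyond the scatter). The earlier step on the other aryl group, a 1.4-fold higher number from compound 1 to compound 2 (0.14 log units; within the scatter), did not separate its two compounds, so this oxygen is the first place shown where a single change clearly alters the number. Nothing measured here explains this shift.

Still open, as far as these compounds go, is whether losing the hydroxy hydrogen or adding the methyl matters more. An amine or a longer ethoxy group in place of the hydroxy could help tell these apart.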